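This account rests on a few compounds, and the source may have more. Where it says the series, first, only, none or still open, it means among the compounds named here.

For the measured compounds named here, in an assay on isolated protein for inhibition of Alpha glucosidase (Homo sapiens), with stated times of 5 min and 15 min, tested at 50 uM (on this read-out lower numbers stand for less inhibition and higher numbers for more inhibition at the one concentration tested (going by the name of the read-out)), compound 2 `Cc1ccc(/C=C2\CCC/C(=C\c3ccccc3)C2=O)cc1` gives 34.1%, the lower of the two numbers measured so far; compound 1 `O=C1/C(=C/c2ccccc2)CCC/C1=C\c1cccc(O)c1` gives 65.1% in this assay. Compound 3 `O=C1/C(=C/c2ccccc2)CCC/C1=C\c1ccccc1F` differs from compound 2 by one change: 2-fluorophenyl in place of 4-methylphenyl on a double-bonded chain carbon bound to a double-bonded ring carbon. Going by the values given here, the only measured step, a number 31 percentage points lower from compound 1 to compound 2 (beyond the scatter), concerns a different group at the same place and shows that this position can move the read-out strongly, but no measured step involves a fluorophenyl, so the direction of the new step is uncertain. Compound 3 is expected to give 40%, within 20% to 62%, so that a step of a number 5.9 percentage points higher from compound 2 to compound 3 (within the scatter) is estimated.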

Compound 3, a percentage reported as inhibition, at one concentration (the size of the read-out at that concentration, not a potency): 43%
Compound 3: the middle estimate sits 3 percentage points below what was measured; low and high end bracket the measured number.
By their numbers in this assay, from the lowest: compounds 2 and 3 (each within the scatter of the next); then compound 1.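

In this assay, 2-fluorophenyl in place of 4-methylphenyl gives a number 8.9 percentage points higher from compound 2 to compound 3 (within the scatter), so these two groups cannot be told apart at this place on the shared core. In place of 3-hydroxyphenyl, 2-fluorophenyl gives a number 22.1 percentage points lower from compound 1 to compound 3 (beyond the scatter), so the 3-hydroxyphenyl group now stands apart from both other groups shown here. Nothing available explains this difference.

The compounds shown leave open whether a 3-methoxyphenyl or 3-aminophenyl group would read like 3-hydroxyphenyl. They also leave open whether 3-fluorophenyl or 4-fluorophenyl would read like 2-fluorophenyl.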